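Thiazole amide replaces pyridine amide on the shared core

This account rests on a few compounds, and the source may have more. Where it says the series, first, only, none or still open, it means among the compounds named here.

Compound 1 `COc1ccc2nc(C)cc(OCC(=O)Nc3cc(C)cc(C)c3)c2c1`: 20000 nM
Compound 2 `COc1ccc2nc(C)cc(OCC(=O)Nc3c(C)cccc3C)c2c1`: > 100000 nM
Compound 3 `COc1ccc2nc(C)cc(OCC(=O)Nc3ccncc3)c2c1`: > 100000 nM

In a toxicity assay on HepG2 cells (Homo sapiens) for inhibition, read by CellTiter-Glo, with a stated time of 48 h (a lower number here means a stronger inhibitor, a higher number a weaker inhibitor), compound 1 gives 20000 nM. For compound 2 only a limit of the assay is recorded, > 100000 nM. Compound 3 likewise stands at a limit of the assay, > 100000 nM, so no number is known for it. Two of the three values shown sit at the limit of > 100000 nM in this assay, at which 2 of the 3 values shown sit. The measured steps run an at least 5.0-fold higher number from compound 1 to compound 2 (0.69 log units; beyond the scatter) and an at least 5.0-fold higher number from compound 1 to compound 3 (0.69 log units; beyond the scatter), while a step that the two limits leave unreadable from compound 2 to compound 3.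

Compound 4 `COc1ccc2nc(C)cc(OCC(=O)Nc3nc(C)c(C)s3)c2c1` has not yet been measured. It differs from compound 3 by 4,5-dimethyl-1,3-thiazol-2-yl in place of pyridin-4-yl on an amide-type nitrogen. Among the compounds with values here, the steps that bear on this change are those from compound 1 to compound 3 and from compound 1 to compound 2, both of which moved away from the one readable number toward the limit; the step from compound 2 to compound 3 gives no size at all. Since compound 3 itself rests at a limit, the step to compound 4 cannot be read in either direction with any confidence, and the expectation is a weak inhibitor, with a fair chance that again only a limit is reported. Compound 4 is therefore expected to come in at about 60000 nM, within 15000 nM to 100000 nM. The step from compound 3 to compound 4 is then estimated as an at least 1.6-fold lower number from compound 3 to compound 4 (0.22 log units; that floor lies within the scatter).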

Compound 4, half-maximal inhibitory concentration: > 100000 nM
Compound 4: only a limit was reported; the forecaster's own chance of this, stated with the estimate: 50%; at least 1.6-fold (0.22 log units) between middle value and limit.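

In this assay compound 4 gives > 100000 nM, which is a limit of the assay and not a number. Within the data shown here, the step against the only readable value in the set is an at least 5.0-fold higher number from compound 1 to compound 4 (0.69 log units; beyond the scatter), so a five-membered aromatic ring carrying sulfur, 4,5-dimethyl-1,3-thiazol-2-yl, joins pyridin-4-yl and 2,6-dimethylphenyl on the amide-type nitrogen in giving no readable number, and among the four compounds only the 3,5-dimethylphenyl group of compound 1 does. The steps from compound 2 and from compound 3 to compound 4 cannot be read, as both ends of each are limits, and the change of ring therefore shows no difference from those two compounds, with most of the set now resting at one ceiling: the limit of > 100000 nM in this assay, at which 3 of the 4 values shown sit.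

As far as these compounds go, how far compound 2, compound 3 and compound 4 lie beyond that limit stays unknown, so these three groups cannot be ranked against one another. Also open, from the compounds shown here alone, is what an unsubstituted phenyl, a 3,5-dichlorophenyl or an unsubstituted 1,3-thiazol-2-yl group would give on the same amide-type nitrogen of the shared core.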